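This account rests on a few compounds, and the source may have more. Where it says the series, first, only, none or still open, it means among the compounds named here.

Working notes on the series. In a functional assay on the whole organism for inhibition, with Mus musculus as the target, in the maximal electroshock model, at a dose of 30 mg/kg by the oral route (a higher number here means a stronger effect of the compound at the dose given, a lower number a weaker effect), compound 1 `CC1(C)CC12NC(=O)N(c1ccccc1)C2=O` gives 80%. Compound 2 `Cc1ccc(N2C(=O)NC3(CC3(C)C)C2=O)cc1` gives 50%, and compound 3 `COc1ccc(N2C(=O)NC3(CC3(C)C)C2=O)cc1` gives 60%, so compound 3 stands second highest of the three numbers, apart from compound 1 beyond the scatter and within the scatter of compound 2. Compound 4 `CC1(C)CC12NC(=O)N(c1ccc(F)cc1)C2=O` differs from compound 3 as follows: fluoro in place of methoxy on an aromatic carbon. Within the data shown here, no measured step exchanges these two groups. Among the measured compounds shown here, the steps that bear on it are a number 30 percentage points lower from compound 1 to compound 2 (beyond the scatter) and a number 20 percentage points lower from compound 1 to compound 3 (beyond the scatter), each a modest lowering on adding a group at this aromatic carbon, while a number 10 percentage points higher from compound 2 to compound 3 (within the scatter). A further small group there is therefore expected to leave the number near compound 3, and the step of no change at the digits printed from compound 3 to compound 4 (within the scatter) is expected to stay within the scatter. Compound 4 is estimated at 60%, between 40% and 80%.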

Compound 4, a percentage reported as inhibition, in the whole organism at one dose (the size of the read-out at that dose, not a potency): 80%
Beside the measured number, compound 4's estimate is 20 percentage points below it; measured number inside the range.
By their numbers in this assay, from the lowest: compounds 2 and 3 (each within the scatter of the next); then compounds 1 and 4 (each within the scatter of the next).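

In this assay the aromatic carbon para to a large group can carry a substituent with no loss, as fluoro gives no change at the digits printed from compound 1 to compound 4 (within the scatter), whereas methyl and methoxy both lowered the number. The lowering is thus specific to the group, not general to substitution here, with a number 20 percentage points higher from compound 3 to compound 4 (beyond the scatter) and a number 30 percentage points higher from compound 2 to compound 4 (beyond the scatter), both beyond the scatter. Nothing available bears on why fluoro parts from methoxy and methyl.

On these data alone, whether chloro or trifluoromethyl at this carbon would also match compound 1 remains open. So does the outcome with an amine or a carboxylic acid there.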